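The source may report more compounds than this note shows. Statements on the series, on what has been measured and on what is new or still open speak of the compounds shown alone.

Measured so far in a functional assay on MCF7 cells (Homo sapiens) for cytotoxicity, read by CCK-8 assay, with a stated time of 24 h; a lower number here means a stronger inhibitor, a higher number a weaker inhibitor:
- compound 2 `C/C(=C\c1nc(-c2ccccc2)cs1)C(N)=O`: 2380 nM
- compound 1 `C/C(=C\c1cc(-c2ccc(C)nc2)co1)C(N)=O`: 10200 nM

Compound 2 stands with the lowest of the two numbers in this assay; compound 1 is its nearest neighbour, with a higher number, and that gap lies beyond the scatter. Compound 3 `C/C(=C\c1nc(-c2ccc(F)cc2)cs1)C(N)=O` has not yet been measured. It differs from compound 2 by fluoro in place of hydrogen on an aromatic carbon. Among the measured compounds shown here, no measured pair shows this change, so its size is unknown; a step within the scatter, in either direction, is expected. The expected step is a 1.2-fold lower number from compound 2 to compound 3 (0.08 log units; within the scatter). Compound 3 is accordingly estimated at 2000 nM, between 800 nM and 6000 nM.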

Compound 3, half-maximal inhibitory concentration: 3300 nM
Compound 3: the middle estimate sits 1.7-fold (0.22 log units) below what was measured, within the range that was stated.
By their numbers in this assay, from the lowest: compounds 2 and 3 (each within the scatter of the next); then compound 1.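

In this assay the change of fluoro in place of hydrogen on an aromatic carbon, para to a large group, gives a 1.4-fold higher number from compound 2 to compound 3 (0.14 log units; within the scatter) and so leaves the number at this position unchanged within the scatter. Among the compounds shown here, this is the first measured pair to show the size of this change at this position. No measurement shown here bears on why the step is this size. The compounds shown leave open whether a chlorine, a methoxy group or an amine at this place would give a step beyond the scatter. They also leave open how fluoro would act elsewhere on this ring.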